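Stretching the amine chain in a cinnamanilide series

This account rests on a few compounds, and the source may have more. Where it says the series, first, only, none or still open, it means among the compounds named here.

Measured so far:
compound 1 `COc1cc(/C=C/C(=O)Nc2ccccc2)ccc1OCCCCN1CCCCC1` 1.61
compound 2 `COc1cc(/C=C/C(=O)Nc2ccccc2)ccc1OCCCCCN(C)C` 1.61

In a physicochemical assay for lipophilicity, using the shake flask method, measured as octanol-water partition, at pH 7.4 (a higher number here means a more lipophilic compound, a lower number a more polar compound), compound 1 gives 1.61, level with compound 2 within the scatter: no change at the digits printed from compound 1 to compound 2 (within the scatter). Compound 3 `COc1cc(/C=C/C(=O)Nc2ccccc2)ccc1OCCCCCCCCCCN(C)C` is not yet measured. It differs from compound 1 by 6-(dimethylamino)hexyl in place of piperidin-1-yl on a saturated chain carbon, four bonds along the chain from an oxygen on an aromatic ring. Among the measured compounds shown here, the only measured step, from compound 1 to compound 2, swaps the ring for a short open chain without change; compound 3 instead carries a much longer chain, so a clearly larger value is expected, a rise of a number 1.79 log units higher from compound 1 to compound 3 (beyond the scatter). Compound 3 is estimated at 3.4, between 2.6 and 4.3.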

Compound 3, partition coefficient: 1.8
Compound 3: middle estimate off by 1.60 log units, on the high side; the measured number lies below the stated range.
By their numbers in this assay, from the lowest: compounds 1, 2 and 3 (each within the scatter of the next).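

In this assay the step reads a number 0.19 log units higher from compound 1 to compound 3 (within the scatter) for 6-(dimethylamino)hexyl in place of piperidin-1-yl and a number 0.19 log units higher from compound 2 to compound 3 (within the scatter) for 5-(dimethylamino)pentyl in place of dimethylamino. The first swap, ring for open chain, could not show this: on this saturated chain carbon, even the much longer chain of compound 3 reads level with both shorter groups. Nothing measured here offers an explanation for that flat reading.

Going by these compounds, it remains open whether a carboxylic acid at the chain end, in place of the amine, would also read level. Whether a still longer chain would do so is open too.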